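A few compounds are considered here, and "the series" means these few. Any claim that something is new, unique, unknown or untested is made for them only; others in the source may bear on it.

Of the compounds shown here, two that share one core have so far been measured in an assay on membranes from HeLa cells for displacement of a labelled ligand from adenosine receptor A3 (Homo sapiens), read by scintillation counting, with a stated time of 180 min, tested at 1 uM; a lower number here means less inhibition, a higher number more inhibition at the concentration tested (going by the name of the read-out). Compound 1 `CC1=C(C(=O)C2CC2)C(c2ccco2)NC(=O)N1` gives 7% in this assay, and compound 2 `CCCC(=O)C1=C(C)NC(=O)NC1c1ccco1` gives 1%. For the measured compounds named here, compound 2 holds the lowest of the two numbers, and the single measured step, a number 6 percentage points lower from compound 1 to compound 2 (within the scatter), stays within the scatter, so the two values cannot be told apart.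

Compound 3 `CC1=C(C(=O)CC(C)C)C(c2ccco2)NC(=O)N1` is not yet measured. It differs from compound 2 by methyl in place of hydrogen on a saturated chain carbon bound to two saturated chain carbons. Going by the values given here, the only measured step that bears on this change is the one from compound 1 to compound 2, which also reshaped the chain on the carbonyl and gave a number 6 percentage points lower from compound 1 to compound 2 (within the scatter). Among the compounds with values here, with that step within the scatter and only one chain change on record, no movement beyond the scatter is expected here either.

Compound 3 is therefore estimated at 3%, with a range from -8% to 14%. The expected step is a number 2 percentage points higher from compound 2 to compound 3 (within the scatter).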

Compound 3, a percentage reported as inhibition, at one concentration (the size of the read-out at that concentration, not a potency): 31%
Compound 3: the middle estimate sits 28 percentage points below what was measured, and the stated range ends below it.
By their numbers in this assay, from the lowest: compounds 2 and 1 (each within the scatter of the next); then compound 3.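

On the saturated chain carbon bound to two saturated chain carbons, one added methyl is enough to register in this assay: the step is a number 30 percentage points higher from compound 2 to compound 3 (beyond the scatter), whereas the earlier change on the carbonyl carbon stayed within the scatter. Isobutyl also separates from cyclopropyl on that carbonyl carbon, with a number 24 percentage points higher from compound 1 to compound 3 (beyond the scatter), so among the three chains shown, only isobutyl stands apart from the other two. Nothing measured here explains why this single methyl changes the number so much.

The compounds shown leave open whether a longer chain or a tert-butyl group on the carbonyl carbon would raise the number further or lose the gain. They also leave open whether an amine on the isobutyl chain would keep the gain seen with compound 3.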